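Chloro for methoxy on the aryl piperazine, two linker lengths

The compounds below may be only part of what the source reports. "The series", "measured", "known", "first", "only" and "open" are said of these compounds alone.

Compound 1 `COc1ccccc1N1CCN(CCn2c(=O)[nH]c3cc(-c4ccccc4)[nH]c3c2=O)CC1` is the reference point of this small set. In an assay for binding affinity to Adrenergic receptor alpha-1 (Rattus norvegicus) (a higher number here means a weaker inhibitor, a lower number a stronger inhibitor), compound 1 gives 0.52 nM. Compound 2 `O=c1[nH]c2cc(-c3ccccc3)[nH]c2c(=O)n1CCN1CCN(c2ccccc2Cl)CC1` carries the change (chloro in place of methoxy on an aromatic carbon), and in this assay compound 2 gives 1.08 nM. Among the compounds with values here, the resulting step, a 2.1-fold higher number from compound 1 to compound 2 (0.32 log units; beyond the scatter), is the only measured instance of this change among the compounds here.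

Compound 3 `COc1ccccc1N1CCN(CCCn2c(=O)[nH]c3cc(-c4ccccc4)[nH]c3c2=O)CC1` has a different core from compound 1; the difference between the two cores is not broken down here. In this assay compound 3 gives 1.23 nM. Against compound 1 this lies beyond the scatter, against compound 2 it lies within it, so no order between compound 2 and compound 3 is claimed.

Compound 4 `O=c1[nH]c2cc(-c3ccccc3)[nH]c2c(=O)n1CCCN1CCN(c2ccccc2Cl)CC1` has not been measured. It differs from compound 3 by chloro in place of methoxy on an aromatic carbon, the same change as that from compound 1 to compound 2, and the place is described in identical words for both pairs. Within the data shown here, the expectation for compound 4 therefore rests on the single step of a 2.1-fold higher number from compound 1 to compound 2 (0.32 log units; beyond the scatter), taken together with the starting number of compound 3, which in this assay is 1.23 nM. In this assay, among the measured compounds shown here, the expected step is a 2.0-fold higher number from compound 3 to compound 4 (0.31 log units; beyond the scatter), with a wide range because only one measured instance, a 2.1-fold higher number from compound 1 to compound 2 (0.32 log units; beyond the scatter), supports it. Compound 4 is estimated at 2.5 nM, within a range from 1.2 nM to 5.5 nM.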

Compound 4, inhibition constant: 62.4 nM
Compound 4: middle estimate off by 25-fold (1.40 log units), on the low side; the measured number lies above the stated range.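

In this assay, chloro in place of methoxy on an aromatic carbon gives a 51-fold higher number from compound 3 to compound 4 (1.71 log units; beyond the scatter), so the size of this change does not carry from the core of compound 1 to the core of compound 3: the same change on two cores in this assay, a 2.1-fold higher number (0.32 log units; beyond the scatter) from compound 1 to compound 2 and a 51-fold higher number (1.71 log units; beyond the scatter) from compound 3 to compound 4, 24-fold (1.39 log units) apart, beyond the scatter of two such steps

The number rises on both cores, but that shared direction rests on just two pairs, and the size of the step depends on the core it is made on. These two pairs do not show which feature of the core difference sets the size of the step, nor whether the large step or the modest one is the more typical for this series, so a step measured on one core is a poor guide to the same change on another.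

Still open, as far as these compounds go, is how the same place responds to other groups on these cores, such as fluoro, methyl or ethoxy in place of methoxy, and whether any of them also gives steps that differ so widely between cores. Also open, from the compounds shown here alone, is how the chloro and methoxy pair behaves on a core with a longer chain, which would show whether the large step stays confined to the core of compound 3.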